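Extending the chain, then trading ethyl for hydroxymethyl

The source may report more compounds than this note shows. Statements on the series, on what has been measured and on what is new or still open speak of the compounds shown alone.

Measured so far:
- compound 1, `CCc1cc(C(C)=O)c(O)cc1OCCCCC#N`: 57%
- compound 2, `CCc1cc(C(C)=O)c(O)cc1OCCCCCCC#N`: 73%

The two measured compounds share one core and differ only in the chain that carries the nitrile. In an assay on isolated protein for binding affinity to leukotriene B4 receptor 1 (Homo sapiens), tested at 1 uM (on this read-out lower numbers stand for less inhibition and higher numbers for more inhibition at the one concentration tested (going by the name of the read-out)), compound 1 gives 57%, and compound 2 gives 73%. Going by the values given here, the one measured step, a number 16 percentage points higher from compound 1 to compound 2 (beyond the scatter), is a modest rise that exceeds the scatter. Among the compounds with values here, on these two numbers compound 2 stands highest, with compound 1 the only neighbour, lower by that same modest step.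

Compound 3, `CC(=O)c1cc(CO)c(OCCCCCCC#N)cc1O`, keeps the longer chain of compound 2 and changes a different part of the core: hydroxy in place of methyl on a saturated chain carbon bound to an aromatic carbon. Within the data shown here, no measured step touches this part of the molecule; the one step known concerns the nitrile chain only, so it gives no direct guide to this swap. With nothing to point either way, the expected step of a number 8 percentage points lower from compound 2 to compound 3 (within the scatter) is taken as none beyond the scatter, with a wide range on both sides. For compound 3 the estimate in this assay is 65%, expected to lie between 40% and 85%.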

Compound 3, a percentage reported as inhibition, at one concentration (the size of the read-out at that concentration, not a potency): 8%
Beside the measured number, compound 3's estimate is 57 percentage points above it, and the stated range ends above it.
By their numbers in this assay, from the lowest: compound 3; then compound 1; then compound 2.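

In this assay, the change from ethyl to hydroxymethyl gives a number 65 percentage points lower from compound 2 to compound 3 (beyond the scatter), a large step set against the modest one seen on the nitrile chain, a number 16 percentage points higher from compound 1 to compound 2 (beyond the scatter). This shows that the saturated chain carbon bound to an aromatic carbon is a sensitive place in the molecule: exchanging one heavy atom, a methyl for a hydroxy, which adds one hydrogen-bond donor and one hydrogen-bond acceptor, removes most of the inhibition that compound 2 shows at the one concentration tested. No available measurement explains why so small a change has so large an effect on this read-out.

Still open, going by these compounds, is whether the same swap would produce a drop of similar size on the shorter nitrile chain of compound 1, since the two changes appear together only in a single pair of steps. Also open, on these data alone, is how other groups in place of the ethyl would read, such as methoxymethyl, aminomethyl or propyl, which could help separate the effect of the hydroxy from that of the chain it sits on.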